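A Methyl Added to the Phenethyl Chain of Compound 2

This account rests on a few compounds, and the source may have more. Where it says the series, first, only, none or still open, it means among the compounds named here.

Compound 1, `c1ccc(CC2CCN(CCCc3c[nH]c4ccc(-n5cnnc5)cc34)CC2)cc1`: 19 nM in an assay on CHO cells for displacement of a labelled ligand from 5-hydroxytryptamine receptor 1B (Homo sapiens); a lower number here means a stronger inhibitor, a higher number a weaker inhibitor
Compound 2, `FC1(CCc2ccccc2)CCN(CCCc2c[nH]c3ccc(-n4cnnc4)cc23)CC1`: 49 nM
Compound 3, `Fc1ccc(CCC2(F)CCN(CCCc3c[nH]c4ccc(-n5cnnc5)cc34)CC2)cc1`: 25 nM

In this assay compound 2 gives 49 nM and compound 1 gives 19 nM, a gap beyond the scatter, while the step of a 2.0-fold lower number from compound 2 to compound 3 (0.29 log units; within the scatter) stays within it. Compound 4, `CC(CC1(F)CCN(CCCc2c[nH]c3ccc(-n4cnnc4)cc23)CC1)c1ccccc1`, differs from compound 2 by methyl in place of hydrogen on a saturated chain carbon bound to an aromatic carbon and a saturated chain carbon. For the measured compounds named here, no measured step touches this part of the molecule: the single step on record, a 2.0-fold lower number from compound 2 to compound 3 (0.29 log units; within the scatter), concerns a fluoro on an aromatic carbon, and compound 1 differs from compound 2 in two places at once. With nothing that bears on the change, a shift no larger than the scatter is expected. The expected step of a 1.0-fold higher number from compound 2 to compound 4 (0.01 log units; within the scatter) reflects this. Compound 4 is therefore estimated at 50 nM, from 17 nM to 150 nM.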

Compound 4, half-maximal inhibitory concentration: 28 nM
Estimate against measurement, compound 4: 1.8-fold (0.25 log units) above; the range from low to high includes it.
By their numbers in this assay, from the lowest: compounds 1, 3, 4 and 2 (each within the scatter of the next, the first and the last beyond it).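

On the saturated chain carbon bound to an aromatic carbon and a saturated chain carbon, methyl in place of hydrogen leaves the number in this assay essentially unmoved, with a 1.8-fold lower number from compound 2 to compound 4 (0.24 log units; within the scatter), so this position accepts the added methyl. The swap of 4-fluorobenzyl for 1-phenylethyl gives a 1.1-fold higher number from compound 3 to compound 4 (0.05 log units; within the scatter), so these two groups cannot be told apart here. Nothing available explains this result. From the compounds shown here alone, whether this carbon also accepts an ethyl, a hydroxyl or an amine remains open, as does whether the methyl would give the same step alongside the aromatic fluoro.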